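The source may hold more compounds than are shown below. What is called first, only, known or untested is meant among the compounds shown, and "the series" means these compounds.

Measured compounds:
compound 1 `CO[C@@H]1CC=C2NN(c3ccc([N+](=O)[O-])cc3)C(=O)CC[C@]2(c2ccccc2)O1` — 9200 nM
compound 2 `COc1ccc(N2NC3=CC[C@@H](OC)O[C@@]3(c3ccccc3)CCC2=O)cc1` — 4100 nM

In a functional assay on DU-145 cells (Homo sapiens) for cytotoxicity, read by sulforhodamine B assay, with a stated time of 48 h (on this read-out lower numbers stand for stronger inhibition and higher numbers for weaker inhibition), compound 1 gives 9200 nM, the highest of the two numbers; its nearest neighbour is compound 2, which gives 4100 nM. Within the data shown here, the one recorded step, a 2.2-fold lower number from compound 1 to compound 2 (0.35 log units; beyond the scatter), puts methoxy in place of nitro on an aromatic carbon and was modest. Compound 3 `CO[C@@H]1CC=C2NN(c3cc(Cl)cc(Cl)c3)C(=O)CC[C@]2(c2ccccc2)O1` differs from compound 1 by 3,5-dichlorophenyl in place of 4-nitrophenyl on an amide-type nitrogen in a ring. Among the measured compounds shown here, no measured step covers the 3,5-dichlorophenyl itself, so only that swap away from 4-nitrophenyl offers guidance. Compound 3 is therefore expected to land near or somewhat under compound 1, a step of a 1.5-fold lower number from compound 1 to compound 3 (0.19 log units; within the scatter), with an estimate of 6000 nM between 2500 nM and 15000 nM.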

Compound 3, half-maximal inhibitory concentration: 8460 nM
Beside the measured number, compound 3's estimate is 1.4-fold (0.15 log units) below it; measured number inside the range.
By their numbers in this assay, from the lowest: compound 2; then compounds 3 and 1 (each within the scatter of the next).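

In this assay, 3,5-dichlorophenyl in place of 4-nitrophenyl on the amide-type nitrogen gives a 1.1-fold lower number from compound 1 to compound 3 (0.04 log units; within the scatter) and so does not separate compound 3 from compound 1. Against the 4-methoxyphenyl of compound 2, the same group gives a 2.1-fold higher number from compound 2 to compound 3 (0.31 log units; beyond the scatter) and so shows that compound 2 alone stands apart among the three. Nothing available explains these differences.

The compounds shown leave open whether an amine or a carboxylic acid on this phenyl ring would move the number. They also leave open whether the phenyl ring is needed at this position at all.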